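This account rests on a few compounds, and the source may have more. Where it says the series, first, only, none or still open, it means among the compounds named here.

Compound 1 `Cc1c(C(=O)OC(C)(C)C)c[nH]c1C(=O)OC(C)(C)C` gives 100 nM in an assay on CHO cells for inhibition of metabotropic glutamate receptor 1 (Rattus norvegicus); on this read-out lower numbers stand for stronger inhibition and higher numbers for weaker inhibition. Among the measured compounds shown here, compound 3 `Cc1c(C(=O)OC(C)C(C)(C)C)c[nH]c1C(=O)OC(C)(C)C` carries 1,2,2-trimethylpropyl in place of tert-butyl on an oxygen next to a carbonyl group, and in this assay compound 3 gives 17 nM; the step of a 5.9-fold lower number from compound 1 to compound 3 (0.77 log units; beyond the scatter) is the only change between measured compounds that differs in one place. Compound 2 `CCCOC(=O)c1[nH]c(C(=O)NCC2CC2)c(C(=O)OC(C)(C)C)c1C` gives 2500 nM in this assay, the highest of the three numbers, with compound 1 and compound 3 both well below it.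

Compound 4 `CCCOC(=O)c1[nH]c(C(=O)Sc2ccccn2)c(C(=O)OC(C)(C)C)c1C` differs from compound 2 by (pyridin-2-yl)sulfanyl in place of (cyclopropylmethyl)amino on a carbonyl carbon. For the measured compounds named here, no measured step touches this part of the shared core: the single step, from compound 1 to compound 3, concerns the group on an ester oxygen and says nothing about the carbonyl carbon that is altered here. The account therefore rests on the value of compound 2 alone. The step of a 1.3-fold lower number from compound 2 to compound 4 (0.10 log units; within the scatter) is expected to stay small, with wide uncertainty in either direction. Compound 4 is estimated at 2000 nM, within a range of 400 nM to 10000 nM.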

Compound 4, half-maximal inhibitory concentration: 3200 nM
Compound 4: the middle estimate sits 1.6-fold (0.20 log units) below what was measured; low and high end bracket the measured number.
By their numbers in this assay, from the lowest: compound 3; then compound 1; then compounds 2 and 4 (each within the scatter of the next).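

In this assay, among the compounds shown here, (pyridin-2-yl)sulfanyl in place of (cyclopropylmethyl)amino on a carbonyl carbon gives a step, a 1.3-fold higher number from compound 2 to compound 4 (0.11 log units; within the scatter), that is the first reading at this carbonyl carbon. Across this pair, the hydrogen-bond donor and the three-membered carbon ring leave and a six-membered aromatic ring with sulfur enters, with no difference beyond the scatter. Nothing measured here explains why these two groups read alike.

The compounds shown leave open whether a carboxylic acid, a simple methylamino group or a longer alkyl chain on this carbonyl carbon would also read alike. Also open, as far as these compounds go, is whether a step like a 5.9-fold lower number from compound 1 to compound 3 (0.77 log units; beyond the scatter) on the ester oxygen would recur with 1,2,2-trimethylpropyl on compound 2 or compound 4.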